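Replacing the 4-nitrophenyl group of compound 3

The source may report more compounds than this note shows. Statements on the series, on what has been measured and on what is new or still open speak of the compounds shown alone.

Compound 1 `Cc1cc(=O)c2c(O)cc(OCc3ccc([N+](=O)[O-])cc3)c([C@H]3CCN(C)C[C@H]3O)c2o1` gives 14%
Compound 2 `Cc1cc(=O)c2c(O)c(CN3CCCC3)c(O)c([C@H]3CCN(C)C[C@H]3O)c2o1` gives 38%
Compound 3 `Cc1oc2c([C@H]3CCN(C)C[C@H]3O)c(O)cc(O)c2c(=O)c1C(O)c1ccc([N+](=O)[O-])cc1` gives 0%

These values come from a functional assay on HL-60 cells (Homo sapiens) for inhibition, read by MTT assay, with a stated time of 48 h, tested at 10 uM; on this read-out lower numbers stand for less inhibition of growth and higher numbers for more inhibition of growth at the one concentration tested. Compound 3 stands lowest of the three, and both other compounds lie beyond the scatter above it. Compound 4 `Cc1oc2c([C@H]3CCN(C)C[C@H]3O)c(O)cc(O)c2c(=O)c1C(O)c1ccc(F)c(Br)c1` has 3-bromo-4-fluorophenyl in place of 4-nitrophenyl on a saturated chain carbon bound to an aromatic carbon and an oxygen on a saturated carbon. For the measured compounds named here, no measured pair shows what a change like this does, so any forecast is uncertain. A modest upward step is expected because compound 3 reads 0% and has no room to fall, though the step may stay within the scatter. The estimated change is a number 14 percentage points higher from compound 3 to compound 4 (beyond the scatter). For compound 4 the estimate is 14%, with an expected range from 0% to 38%.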

Compound 4, percent growth inhibition at one concentration: 25%
Beside the measured number, compound 4's estimate is 11 percentage points below it; measured number inside the range.
By their numbers in this assay, from the lowest: compound 3; then compound 1; then compound 4; then compound 2.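

At this place, on a saturated chain carbon bound to an aromatic carbon and an oxygen on a saturated carbon, 3-bromo-4-fluorophenyl in place of 4-nitrophenyl gives a number 25 percentage points higher from compound 3 to compound 4 (beyond the scatter) in this assay and shows that the aryl group here can change the reading. This single step shows one exchange, not a trend. No available evidence accounts for the rise.

The compounds shown leave open whether the bromine, the fluorine or the pair matters, since both enter together. On these data alone, how an unsubstituted phenyl or a carboxylic acid would read at this place also remains open.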